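Nitrooxy acyl pyrazolines: aryl swap on the saturated ring carbon

The source may report more compounds than this note shows. Statements on the series, on what has been measured and on what is new or still open speak of the compounds shown alone.

Compound 1 `COc1ccc(C2=NN(C(=O)CO[N+](=O)[O-])C(c3ccco3)C2)cc1OC` carries furan-2-yl on a saturated ring carbon of the shared core. In a functional assay on the whole organism (strain albino) for inhibition, with Rattus norvegicus as the target, read by paw edema, with stated times of 30 min and 1 h, at a dose of 100 mg/kg by the oral route (a lower number here means less inhibition, a higher number more inhibition at the dose given (going by the name of the read-out)), compound 1 gives 32%. Compound 2 `COc1ccc(C2CC(c3ccc(OC)c(OC)c3)=NN2C(=O)CO[N+](=O)[O-])c(OC)c1` differs from compound 1 by 2,4-dimethoxyphenyl in place of furan-2-yl on a saturated ring carbon. In this assay compound 2 gives 38%, and the step is a number 6 percentage points higher from compound 1 to compound 2 (within the scatter). Compound 3 `COc1ccc(C2=NN(C(=O)C(C)O[N+](=O)[O-])C(c3ccco3)C2)cc1OC` differs from compound 1 by methyl in place of hydrogen on a saturated chain carbon bound to a carbonyl carbon and an oxygen on an unsaturated carbon. In this assay compound 3 gives 35%, which is a step of a number 3 percentage points higher from compound 1 to compound 3 (within the scatter). The values of compound 2 and compound 3 lie within the scatter of each other, so no order among the three measured compounds can be read from this assay.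

Compound 4 `COc1ccc(C2CC(c3ccc(OC)c(OC)c3)=NN2C(=O)C(C)O[N+](=O)[O-])c(OC)c1` has not been measured. It differs from compound 3 by 2,4-dimethoxyphenyl in place of furan-2-yl on a saturated ring carbon. For the measured compounds named here, this is the same kind of change as the one from compound 1 to compound 2, not the same change: the ring atom next to the place bears a ((nitrooxy)methyl)carbonyl group (7 heavy atoms) in compound 1, while in compound 3 it bears a group of 8 heavy atoms, and the two cores differ as already given for compound 3 against compound 1.

Since the same kind of change gave only a number 6 percentage points higher from compound 1 to compound 2 (within the scatter), a step within the scatter, the expected step for compound 4 is a number 6 percentage points higher from compound 3 to compound 4 (within the scatter). Compound 4 is estimated at 41% in this assay, with a range from 30% to 52%.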

Compound 4, a percentage reported as inhibition, in the whole organism at one dose (the size of the read-out at that dose, not a potency): 44%
The estimate for compound 4 lay 3 percentage points below the measured number, within the range that was stated.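

In this assay, 2,4-dimethoxyphenyl in place of furan-2-yl on the saturated ring carbon gives a number 9 percentage points higher from compound 3 to compound 4 (within the scatter), and this step agrees with the earlier one on the other core: the same change on two cores in this assay, a number 6 percentage points higher (within the scatter) from compound 1 to compound 2 and a number 9 percentage points higher (within the scatter) from compound 3 to compound 4, 3 percentage points apart, within the scatter of two such steps

Methyl in place of hydrogen on the chain carbon gives a number 6 percentage points higher from compound 2 to compound 4 (within the scatter), and this step also agrees with its earlier counterpart: the same change on two cores in this assay, a number 3 percentage points higher (within the scatter) from compound 1 to compound 3 and a number 6 percentage points higher (within the scatter) from compound 2 to compound 4, 3 percentage points apart, within the scatter of two such steps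

For the compounds shown here, each change therefore carries from one core to the other with no difference that can be told from the scatter, but with every step itself within the scatter, this shows neither that either change alters inhibition nor that the two changes add up, and it rests on only two cores at a single oral dose.

Going by these compounds, the saturated ring carbon holds only furan-2-yl or 2,4-dimethoxyphenyl in these compounds, so it remains open how an unsubstituted phenyl or a phenyl bearing an amine would behave there. The chain carbon holds only hydrogen or methyl, which leaves open an ethyl or longer chain at that carbon, as well as a hydroxyl or a carboxylic acid in place of the nitrooxy group.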